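Acyl variation on a shared core: expectation for compound 4

The compounds below may be only part of what the source reports. "The series", "measured", "known", "first", "only" and "open" are said of these compounds alone.

Working notes on the series. Three compounds share one core and differ only in the group on the carbonyl carbon. Compound 1 `Cc1nc(C(=O)Nc2ccc(Cl)c(-c3nnc4c(Cl)cccn34)c2)cs1` carries 2-methyl-1,3-thiazol-4-yl there. In a functional assay on MCF7 cells (Homo sapiens) for antiproliferative activity, read by MTT assay, with a stated time of 72 h (on this read-out higher numbers stand for weaker inhibition and lower numbers for stronger inhibition), compound 1 gives only a limit, > 100000 nM. Compound 2 `O=C(Nc1ccc(Cl)c(-c2nnc3c(Cl)cccn23)c1)c1cccnc1` carries pyridin-3-yl on the carbonyl carbon. In this assay compound 2 gives only a limit as well, > 100000 nM. Compound 3 `CS(=O)(=O)c1ccc(C(=O)Nc2ccc(Cl)c(-c3nnc4c(Cl)cccn34)c2)c(Cl)c1` carries a third acyl group. In this assay compound 3 again gives only a limit, > 100000 nM. For the measured compounds named here, the single measured step, a step that the two limits leave unreadable from compound 1 to compound 2, is unreadable in size, since both ends are limits. All three values sit at the limit of > 100000 nM in this assay, at which 3 of the 3 values shown sit, so compound 2 stands with the other two at that limit and nothing separates it from them on the numbers shown.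

Compound 4 `O=C(Nc1ccc(Cl)c(-c2nnc3c(Cl)cccn23)c1)c1ccccc1Cl` differs from compound 2 in one place: 2-chlorophenyl in place of pyridin-3-yl on a carbonyl carbon. Going by the values given here, no measured step bears directly on this exchange, and the one step recorded, a step that the two limits leave unreadable from compound 1 to compound 2, gives no size. Every acyl change so far has left the result at the limit of > 100000 nM in this assay, at which 3 of the 3 values shown sit, so no readable step beyond the scatter is expected in this assay, in either direction. The expected step is a number no higher from compound 2 to compound 4 (the limit leaves the size open). Compound 4 is expected to give 100000 nM, within 30000 nM to 300000 nM, most likely reported once more only as a limit.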

Compound 4, half-maximal inhibitory concentration: 92200 nM
The estimate for compound 4 lay 1.1-fold (0.04 log units) above the measured number, and the stated range covers the measured number.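

With 2-chlorophenyl on the carbonyl carbon, the series gives its first read-out in this assay that is a number and not a limit, while the other acyl groups stay at that limit: the limit of > 100000 nM in this assay, at which 3 of the 4 values shown sit. Set against pyridin-3-yl the exchange gives an at least 1.0-fold lower number from compound 2 to compound 4 (0.03 log units; that floor lies within the scatter), and set against 2-methyl-1,3-thiazol-4-yl it gives an at least 1.0-fold lower number from compound 1 to compound 4 (0.03 log units; that floor lies within the scatter). Hydrogen in place of methylsulfonyl on an aromatic carbon gives an at least 1.0-fold lower number from compound 3 to compound 4 (0.03 log units; that floor lies within the scatter), so all three steps are floors only and none shows a difference beyond the scatter.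

On these data alone, the true sizes of these steps stay open, and the steps among compounds 1, 2 and 3 cannot be read, since each of those compounds has only a limit. Also open, as far as these compounds go, is whether an acyl group carrying an amine or a carboxylic acid, or a longer alkyl chain on the carbonyl carbon in place of the aromatic ring, would bring the number in this assay beyond the scatter from that of compound 4.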